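The source may report more compounds than this note shows. Statements on the series, on what has been measured and on what is new or still open speak of the compounds shown alone.

Measured so far in an ADME assay on HepG2 cells (Homo sapiens) for cytotoxicity, read by neutral red uptake, with a stated time of 24 h; on this read-out lower numbers stand for stronger inhibition and higher numbers for weaker inhibition
Compound 1 `CCCC(=O)Oc1c(C(C)C)cc2c3c1OC(=O)[C@@]31CCCC(C)(C)[C@@H]1CC2` gives 56100 nM
Compound 2 `CCCCCCCCCCCCCCCC(=O)Oc1c(C(C)C)cc2c3c1OC(=O)[C@@]31CCCC(C)(C)[C@@H]1CC2` gives > 1000000 nM as a limit

Compound 2 stands at > 1000000 nM which is a limit of the assay and not a number. Compound 3 `CCCCC/C=C/C/C=C/CCCCCCCC(=O)Oc1c(C(C)C)cc2c3c1OC(=O)[C@@]31CCCC(C)(C)[C@@H]1CC2` differs from compound 2 in one place (deca-1,4-dien-1-yl in place of octyl on a saturated chain carbon, seven bonds along the chain from a carbonyl carbon) and so carries two double bonds in its chain. Among the measured compounds shown here, the only measured step on this chain is an at least 17-fold higher number from compound 1 to compound 2 (1.25 log units; beyond the scatter) and it was large, but it added length and no double bonds. For the measured compounds named here, no measured step covers double bonds, so no step beyond the scatter is expected, and the estimated step is an at least 1.2-fold lower number from compound 2 to compound 3 (0.09 log units; that floor lies within the scatter) for this change. Compound 3 is expected at 800000 nM with a range from 200000 nM to 2000000 nM and may itself turn out to be only a limit.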

Compound 3, half-maximal inhibitory concentration: 289000 nM
The estimate for compound 3 lay 2.8-fold (0.44 log units) above the measured number, within the range that was stated.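

In this assay, deca-1,4-dien-1-yl in place of octyl, seven bonds along the chain from a carbonyl carbon, gives an at least 3.4-fold lower number from compound 2 to compound 3 (0.53 log units; beyond the scatter). Even this far along the chain, a change still moves the number, and the group with 10 carbon atoms in place of 8 brings it down, so chain length alone does not set the value. This step is only a floor, because the value for compound 2 is a limit of the assay and not a number: the limit of > 1000000 nM in this assay, at which 1 of the 3 values shown sits.

The compounds shown cannot separate the double bonds from the added carbons. Going by these compounds, a saturated decyl group in the same place would test that, and whether a single double bond would be enough stays open.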